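The source may report more compounds than this note shows. Statements on the series, on what has been measured and on what is new or still open speak of the compounds shown alone.

Going by the values given here, compound 2 `O=C(NC(c1cncnc1)c1ccc(Cl)c(Cl)c1)c1ccc2cnccc2c1` is one of two compounds measured in an assay on isolated protein for inhibition of RAC-alpha serine/threonine-protein kinase (Homo sapiens) (a higher number here means a weaker inhibitor, a lower number a stronger inhibitor), and its number is the higher of the two: in this assay compound 2 gives 12700 nM. Among the compounds with values here, the other compound, compound 1 `O=C(NC(c1cnc(Cl)c(Cl)c1)C1CCNCC1)c1ccc2cnccc2c1`, differs from it in more than one place, and in this assay compound 1 gives 140 nM; the two values show only that compound 1 lies far lower, and no single step connects them. Compound 3 `O=C(NC(c1ccncc1)c1ccc(Cl)c(Cl)c1)c1ccc2cnccc2c1` has not yet been measured. It differs from compound 2 in one place: pyridin-4-yl in place of pyrimidin-5-yl on a saturated chain carbon bound to an amide-type nitrogen and an aromatic carbon. Within the data shown here, no measured pair in this set shares that change, so the size of the step is unknown. A moderate step toward a lower number is expected, since the shared core of compound 1 reaches 140 nM in this assay. In this assay compound 3 is therefore estimated at 5000 nM, with a range from 1500 nM to 20000 nM, which would be an expected step of a 2.5-fold lower number from compound 2 to compound 3 (0.40 log units; beyond the scatter).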

Compound 3, half-maximal inhibitory concentration: 20400 nM
Compound 3: middle estimate off by 4.1-fold (0.61 log units), on the low side, and the stated range ends below it.
By their numbers in this assay, from the lowest: compound 1; then compounds 2 and 3 (each within the scatter of the next).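

In this assay, going by these compounds alone, placing pyridin-4-yl instead of pyrimidin-5-yl on the saturated chain carbon bound to an amide-type nitrogen and an aromatic carbon gives a 1.6-fold higher number from compound 2 to compound 3 (0.21 log units; within the scatter), the first single-place step in this set. At this position, then, going from a ring with 2 hetero atoms to one with 1 hetero atom, and from 2 hydrogen-bond acceptors to 1, does not separate the two compounds in this assay. Nothing measured here accounts for this result.

Compound 1 differs from both compounds in more than one place, so no single change can be credited with its number. Going by these compounds, it also remains open whether an aminomethyl group or a carboxylic acid at this carbon would give a number beyond the scatter from that of compound 2.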